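A few compounds are considered here, and "the series" means these few. Any claim that something is new, unique, unknown or untested is made for them only; others in the source may bear on it.

Measured in a toxicity assay on MRC5 cells (Homo sapiens) for inhibition, read by MTT assay, with a stated time of 72 h; on this read-out higher numbers stand for weaker inhibition and lower numbers for stronger inhibition:

compound 1 `COc1cccc(-n2cc(COc3cccc(NC(=O)Nc4ccc(Cl)c(C(F)(F)F)c4)c3)nn2)c1` — 8570 nM
compound 2 `O=C(Nc1cccc(OCc2cn(-c3ccc(F)cc3)nn2)c1)Nc1ccc(Cl)c(C(F)(F)F)c1` — 4740 nM
compound 3 `O=C(Nc1cccc(OCc2cn(-c3ccc(Br)cc3)nn2)c1)Nc1ccc(Cl)c(C(F)(F)F)c1` — 11000 nM

Compound 3 carries the highest of the three numbers. Its gap to compound 1 is small, a 1.3-fold higher number from compound 1 to compound 3 (0.11 log units; within the scatter), whereas the gap to compound 2 is real though modest, a 2.3-fold higher number from compound 2 to compound 3 (0.37 log units; beyond the scatter); compound 1 and compound 2 sit within scatter of each other, a 1.8-fold lower number from compound 1 to compound 2 (0.26 log units; within the scatter).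

Compound 4 `O=C(Nc1cccc(OCc2cn(-c3ccc(I)cc3)nn2)c1)Nc1ccc(Cl)c(C(F)(F)F)c1` continues the halogen row: iodo in place of bromo on an aromatic carbon. Only the fluoro-to-bromo step bears on it, and that step was modest. Going one halogen further, a step of similar size or none beyond the scatter is expected, a 1.2-fold higher number from compound 3 to compound 4 (0.07 log units; within the scatter). Compound 4 is therefore estimated at 13000 nM in this assay, range 6000 nM to 28000 nM.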

Compound 4, half-maximal inhibitory concentration: 6840 nM
Compound 4: middle estimate off by 1.9-fold (0.28 log units), on the high side; the measured number falls inside the stated range.
By their numbers in this assay, from the lowest: compounds 2, 4, 1 and 3 (each within the scatter of the next, the first and the last beyond it).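

In this assay the iodo compound does not continue the rise seen from fluoro to bromo: both its steps within the halogen row stay within the scatter (a 1.6-fold lower number from compound 3 to compound 4 (0.21 log units; within the scatter)) (a 1.4-fold higher number from compound 2 to compound 4 (0.16 log units; within the scatter)), so compound 4 goes against any steady climb along that row. The 4-iodophenyl group also cannot be told apart from 3-methoxyphenyl at this place (a 1.3-fold lower number from compound 1 to compound 4 (0.10 log units; within the scatter)). No available evidence accounts for these numbers. Open, going by these compounds, is whether an amine or a carboxylic acid on this aromatic ring, in place of the halogen, would move the number beyond the scatter.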